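Removing One Methyl from the Anilide Ring

This account rests on a few compounds, and the source may have more. Where it says the series, first, only, none or still open, it means among the compounds named here.

In a functional assay on HL-60 cells (Homo sapiens) for antiproliferative activity, read by MTT assay, with a stated time of 48 h (on this read-out higher numbers stand for weaker inhibition and lower numbers for stronger inhibition), the compounds in this series are compared through one shared core. Compound 1 `C=CC(=O)Nc1ccc(-c2nc(Cl)cc(Nc3ccc(C(=O)Nc4ccc(F)cc4)cc3)n2)cc1` gives "not determined" (no result reported) in this assay, so no number is available for it. Compound 2 `C=CC(=O)Nc1ccc(-c2nc(Cl)cc(Nc3ccc(C(=O)Nc4cc(C(F)(F)F)cc(C(F)(F)F)c4)cc3)n2)cc1` gives 4790 nM in this assay, while compound 3 `C=CC(=O)Nc1ccc(-c2nc(Cl)cc(Nc3ccc(C(=O)Nc4cc(C)ccc4C)cc3)n2)cc1` gives 14900 nM in this assay. Compound 3 therefore stands at the highest of the two numbers available, and its gap to compound 2 lies beyond the scatter, so compound 3 is the weaker of the two measured compounds in this assay.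

Compound 4 `C=CC(=O)Nc1ccc(-c2nc(Cl)cc(Nc3ccc(C(=O)Nc4cccc(C)c4)cc3)n2)cc1` differs from compound 3 in one place only: hydrogen in place of methyl on an aromatic carbon. Among the compounds with values here, no measured pair in this set shows the same change, so the direction of the step cannot be read from a precedent. Within the data shown here, with only two numbers at hand, the step from compound 3 to compound 4 is expected to be small, probably within the scatter, with a slight lean toward stronger inhibition, which is what a 1.7-fold lower number from compound 3 to compound 4 (0.22 log units; within the scatter) expresses. Compound 4 is accordingly expected to give about 9000 nM in this assay, with a range from 3000 nM to 27000 nM.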

Compound 4, half-maximal inhibitory concentration: 3660 nM
Beside the measured number, compound 4's estimate is 2.5-fold (0.39 log units) above it, and the stated range covers the measured number.
By their numbers in this assay, from the lowest: compounds 4 and 2 (each within the scatter of the next); then compound 3.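

In this assay, within the data shown here, the change from 2,5-dimethylphenyl to 3-methylphenyl gives the first readable step: a 4.1-fold lower number from compound 3 to compound 4 (0.61 log units; beyond the scatter). This shows that the position ortho to a large group and para to a methyl group is not neutral, since hydrogen there gives stronger inhibition than methyl while the other methyl group stays in place. No measurement of any property of these compounds bears on this step, so its origin stays unexplained.

This single pair cannot show whether a fluorine atom, a methoxy group or an amine at the same position would behave like the hydrogen or like the methyl. It also leaves open what replacing the remaining methyl group with hydrogen would do.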